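A halogen swap on the aryl ring of compound 2

The compounds below may be only part of what the source reports. "The series", "measured", "known", "first", "only" and "open" are said of these compounds alone.

Three compounds share one core and differ only in the aryl group carried on a nitrogen on an aromatic ring. In a functional assay on HeLa cells (Homo sapiens) for antiproliferative activity, read by spectrophotometry, with a stated time of 2 days (a higher number here means a weaker inhibitor of growth, a lower number a stronger inhibitor of growth), compound 1 `COc1cc(Nc2ncc(C(F)(F)F)c(N3Cc4cccc(N(C)S(C)(=O)=O)c4C3)n2)cc(OC)c1` gives 7000 nM, compound 2 `Cc1ccc(Nc2ncc(C(F)(F)F)c(N3Cc4cccc(N(C)S(C)(=O)=O)c4C3)n2)c(Cl)c1` gives 10900 nM, and compound 3 `CN(c1cccc2c1CN(c1nc(Nc3cccc(Oc4ccccc4)c3)ncc1C(F)(F)F)C2)S(C)(=O)=O` gives 4300 nM. Compound 2 thus has the highest number of the three: its gap to compound 1 is within the scatter, while its gap to compound 3 is beyond it.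

Compound 4 `Cc1cc(F)ccc1Nc1ncc(C(F)(F)F)c(N2Cc3cccc(N(C)S(C)(=O)=O)c3C2)n1` is not yet measured in this assay. It differs from compound 2 by 4-fluoro-2-methylphenyl in place of 2-chloro-4-methylphenyl on a nitrogen on an aromatic ring. Among the measured compounds shown here, the one measured step that bears on such a change of the aryl group is a 1.6-fold higher number from compound 1 to compound 2 (0.19 log units; within the scatter), a step within the scatter. For the measured compounds named here, with only that comparison to go on, compound 4 is expected to show no step beyond the scatter, namely a 1.2-fold lower number from compound 2 to compound 4 (0.08 log units; within the scatter). Compound 4 is therefore estimated at 9000 nM, with a range from 4000 nM to 22000 nM.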

Compound 4, concentration for 50% growth inhibition: 6500 nM
Compound 4: the middle estimate sits 1.4-fold (0.14 log units) above what was measured; the range from low to high includes it.
By their numbers in this assay, from the lowest: compounds 3, 4, 1 and 2 (each within the scatter of the next, the first and the last beyond it).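

In this assay, the exchange of 2-chloro-4-methylphenyl for 4-fluoro-2-methylphenyl on this nitrogen amounts to a 1.7-fold lower number from compound 2 to compound 4 (0.22 log units; within the scatter), and the exchange of 3,5-dimethoxyphenyl for the same group amounts to a 1.1-fold lower number from compound 1 to compound 4 (0.03 log units; within the scatter). A fluorine-bearing aryl group thus joins the chlorine-bearing and dimethoxy aryl groups within the scatter, so three different substitution patterns on this ring cannot be told apart here, although compound 3 and its larger aryl group remain a separate comparison. No measurement at hand accounts for the size of these steps.

The change from compound 2 to compound 4 alters the halogen and the places of both substituents at once, so the compounds shown cannot separate these contributions. They also leave open how an aryl group carrying an amine or a carboxylic acid would read at this nitrogen.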